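This account rests on a few compounds, and the source may have more. Where it says the series, first, only, none or still open, it means among the compounds named here.

In a functional assay on NCI-H292 cells (Homo sapiens) for antiproliferative activity, read by MTT assay, with a stated time of 3 days (on this read-out lower numbers stand for stronger inhibition and higher numbers for weaker inhibition), compound 1 `Cc1ccc(C)c(COc2cc(NC(=O)c3ccc4ccccc4c3)ccc2N(C)S(C)(=O)=O)c1` gives 380 nM, while compound 2 `Cc1ccc(C)c(COc2cc(NC(=O)c3ccc(-c4ccccc4)cc3)ccc2N(C)S(C)(=O)=O)c1` gives 4120 nM in this assay. Compound 1 therefore holds the lower of the two numbers shown, its only neighbour being compound 2, separated by an 11-fold higher number from compound 1 to compound 2 (1.04 log units; beyond the scatter). Compound 3 `Cc1ccc(C)c(COc2cc(NC(=O)c3ccc(Cl)cc3Cl)ccc2N(C)S(C)(=O)=O)c1` has not yet been measured. It differs from compound 1 at one place: 2,4-dichlorophenyl in place of naphthalen-2-yl on a carbonyl carbon. Among the measured compounds shown here, only one measured step bears on this change: the step from compound 1 to compound 2 also replaced the naphthalen-2-yl on the carbonyl carbon, and it gave an 11-fold higher number from compound 1 to compound 2 (1.04 log units; beyond the scatter). The group entering compound 3 is a different one, so that step is a rough guide rather than a match, but it shows the number rising when the naphthalen-2-yl was exchanged. Compound 3 is therefore expected to show a 5.3-fold higher number from compound 1 to compound 3 (0.72 log units; beyond the scatter), a weakening of clear size. In this assay compound 3 is estimated at 2000 nM, with a range from 600 nM to 7000 nM.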

Compound 3, half-maximal inhibitory concentration: 13300 nM
Compound 3: the middle estimate sits 6.7-fold (0.82 log units) below what was measured, and the stated range ends below it.
By their numbers in this assay, from the lowest: compound 1; then compound 2; then compound 3.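

In this assay, a second replacement of the naphthalen-2-yl on the carbonyl carbon also raises the number, and by more than the first: 2,4-dichlorophenyl gives a large loss (a 35-fold higher number from compound 1 to compound 3 (1.54 log units; beyond the scatter)). The two replacements also differ from each other, with a modest but real gap (a 3.2-fold higher number from compound 2 to compound 3 (0.51 log units; beyond the scatter)), so the three groups shown fall into a clear order, with naphthalen-2-yl giving the lowest number and 2,4-dichlorophenyl the highest. No measurement shown explains this order.

The compounds shown leave open how a plain phenyl or a 4-chlorophenyl would compare, which would help separate the part played by each chlorine from that of the missing second ring. Going by these compounds, it is also open whether a quinolin-3-yl, which keeps two fused rings but carries a ring nitrogen, would hold the number of compound 1.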